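A few compounds are considered here, and "the series" means these few. Any claim that something is new, unique, unknown or untested is made for them only; others in the source may bear on it.

Measured compounds:
Compound 1 `CCOC(=O)c1cc(CCCOc2ccc(-c3noc(C(F)(F)F)n3)cc2C(F)(F)F)on1`: 28400 nM
Compound 2 `Cc1cc(-c2noc(C(F)(F)F)n2)cc(C)c1OCCCc1cc(C(=O)OC(C)C)no1`: 17900 nM

Both compounds were tested in an ADME assay on HeLa cells (Homo sapiens) for cytotoxicity, read by crystal violet staining, with a stated time of 72 h; on this read-out lower numbers stand for higher toxicity in this test and higher numbers for lower toxicity in this test. Compound 1 gives 28400 nM there. Compound 2 gives 17900 nM, and this number lies within the usual scatter of the value of compound 1, so the two cannot be set apart on this read-out.

Compound 3 `Cc1cc(-c2noc(C(F)(F)F)n2)cc(C)c1OCCCc1cc(C(=O)NCc2ccccc2)no1` has not yet been tested in this assay. It differs from compound 2 in one place: benzylamino in place of isopropoxy on a carbonyl carbon. Among the measured compounds shown here, no pair of measured compounds shows this change, so there is nothing in the numbers to tell how large a step it brings.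

With only the two values to go on, compound 3 is expected to give a number close to that of compound 2, with the step of a 1.2-fold lower number from compound 2 to compound 3 (0.08 log units; within the scatter) estimated to stay within or only slightly beyond the scatter, in the direction of a lower number. The value of compound 3 is estimated at 15000 nM, within a range from 6000 nM to 40000 nM.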

Compound 3, half-maximal cytotoxic concentration: > 100000 nM
Compound 3 gave a limit, no number; the forecaster's own chance of this, stated with the estimate: 15%; at least 6.6-fold (0.82 log units) between middle value and limit.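

In this assay, among the compounds shown here, the move from isopropoxy to benzylamino on the carbonyl carbon gives an at least 5.5-fold higher number from compound 2 to compound 3 (0.74 log units; beyond the scatter), so this position, which the earlier compounds did not probe in a single change, does respond to what is attached there. Compound 3 reaches only a limit of the assay, > 100000 nM, not a number. The step therefore has a lower bound but no upper end: the limit of > 100000 nM in this assay, at which 1 of the 3 values shown sits.

The change brings in the nitrogen with its hydrogen and the six-membered aromatic ring together, so the compounds shown leave open which of these goes with the step. As far as these compounds go, whether a methylamino group or a carboxylic acid in this place would move the number as far also stays open.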